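From trifluoromethyl to methyl on compound 1

A few compounds are considered here, and "the series" means these few. Any claim that something is new, unique, unknown or untested is made for them only; others in the source may bear on it.

Compound 1 `O=C(O)c1ccc(C(=O)/C(=C\c2ccc(F)c([N+](=O)[O-])c2)SCc2ccc(C(F)(F)F)cc2)cc1`: < 1000 ug/mL
Compound 2 `O=C(O)c1ccc(C(=O)/C(=C\c2ccc(Br)c([N+](=O)[O-])c2)SCc2ccc(Cl)cc2Cl)cc1`: < 1000 ug/mL
Compound 3 `O=C(O)c1ccc(C(=O)/C(=C\c2ccc(Cl)c([N+](=O)[O-])c2)S(=O)(=O)Cc2ccc(Br)cc2)cc1`: < 1000 ug/mL

All three compounds were read in a physicochemical assay for solubility; on this read-out higher numbers stand for higher solubility and lower numbers for lower solubility. Compound 1 gives < 1000 ug/mL, which is a limit and not a number. Compound 2 gives < 1000 ug/mL, also a limit. Compound 3 gives < 1000 ug/mL, again a limit. Compound 1 therefore has no exact place among them, and the evidence so far is the limit of < 1000 ug/mL in this assay, at which 3 of the 3 values shown sit. Among the measured compounds shown here, no two measured compounds differ in only one place, so no measured step is available as a guide.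

Compound 4 `Cc1ccc(CS/C(=C/c2ccc(F)c([N+](=O)[O-])c2)C(=O)c2ccc(C(=O)O)cc2)cc1` has methyl in place of trifluoromethyl on an aromatic carbon, para to a large group: methyl in place of trifluoromethyl on an aromatic carbon. No step beyond the usual scatter is expected in this assay, in either direction, and another limit is the likely report. This expectation rests only on compound 1, whose reading is the limit < 1000 ug/mL. The expected change is a step that the limit leaves unreadable from compound 1 to compound 4. For compound 4 the estimated value is 600 ug/mL, with an expected range from 100 ug/mL to 1000 ug/mL.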

Compound 4, solubility: < 1000 ug/mL
Compound 4: only a limit was reported (the forecaster's own chance of this, stated with the estimate: 85%); the middle value is on the limit's open side.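

Compound 1 and compound 4 are both reported only as limits in this assay, so no step can be read between them. The compounds shown leave open how they rank and what methyl in place of trifluoromethyl does in this assay, with every reading at one limit: the limit of < 1000 ug/mL in this assay, at which 4 of the 4 values shown sit.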